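The source may report more compounds than this note shows. Statements on the series, on what has been measured and on what is new or still open speak of the compounds shown alone.

Of the compounds shown here, three that share one core have been measured in an ADME assay on CCRF-HSB-2 cells (Homo sapiens) for cytotoxicity, with a stated time of 7 days; a lower number here means that less compound is tolerated, a higher number that more compound is tolerated. Compound 1 `CCCCSc1nc(N)nc2c1ncn2/C=C1/CC1(CO)CO` carries a butylsulfanyl group on an aromatic carbon of the core, and in this assay compound 1 gives 89000 nM. Compound 2 `Nc1nc(NC2CC2)c2ncn(/C=C3/CC3(CO)CO)c2n1` carries a cyclopropylamino group in that place; in this assay compound 2 reaches only a limit of the assay, > 20000 nM, not a number. Compound 3 `Nc1nc(NC2CCCC2)c2ncn(/C=C3/CC3(CO)CO)c2n1` carries a cyclopentylamino group, and in this assay compound 3 likewise gives only a limit, > 20000 nM. So compound 2 stands at a limit, together with compound 3, while compound 1 alone has a number.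

Compound 4 `Nc1nc(SC2CCCC2)c2ncn(/C=C3/CC3(CO)CO)c2n1` is not yet measured. It differs from compound 2 as follows: cyclopentylsulfanyl in place of cyclopropylamino on an aromatic carbon. The measured steps that touch this change are a step that the limit leaves unreadable from compound 1 to compound 2, a step that the limit leaves unreadable from compound 1 to compound 3 and a step that the two limits leave unreadable from compound 2 to compound 3, and none of them yields a readable size because of the limit of > 20000 nM in this assay, at which 2 of the 3 values shown sit. What remains is that compound 1, with its butylsulfanyl group, sits at 89000 nM, while compound 4 carries a cyclopentylsulfanyl group. The step that the limit leaves unreadable from compound 2 to compound 4 is therefore expected to be either unreadable or modest. For compound 4 in this assay a value of 60000 nM is estimated, within a range from 15000 nM to 200000 nM.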

Compound 4, half-maximal cytotoxic concentration: 91000 nM
Compound 4: the middle estimate sits 1.5-fold (0.18 log units) below what was measured, within the range that was stated.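

With a sulfur on this aromatic carbon, putting cyclopentyl in place of butyl gives, in this assay, a 1.0-fold higher number from compound 1 to compound 4 (0.01 log units; within the scatter). Within the data shown here, this is the first step at this position with a readable size, and it shows that these two sulfur-linked groups, one an open chain and the other a five-membered ring, cannot be told apart in this measurement. The steps from compound 2 and from compound 3 to compound 4 cannot be read, because each of those two starting compounds gives a limit and not a number: the limit of > 20000 nM in this assay, at which 2 of the 4 values shown sit.

The compounds shown leave open whether the linking atom itself matters: compound 3 and compound 4 both carry a cyclopentyl ring and differ in having a nitrogen or a sulfur as the link, yet no size can be given for that step. They also leave open how a much longer alkyl chain or a phenyl group on the sulfur, or a methoxy group on this aromatic carbon, would behave in this assay.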